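A few compounds are considered here, and "the series" means these few. Any claim that something is new, unique, unknown or untested is made for them only; others in the source may bear on it.

Measured so far:
compound 1, `COc1cccc(CNCCCNc2ccnc3cc(C4CCCCC4)ccc23)c1O`, 23 10^-6 cm/s
compound 2, `COc1ccc(F)cc1CNCCCNc1ccnc2cc(C3CCCCC3)ccc12`, 23 10^-6 cm/s
compound 3, `FC(F)(F)c1cc(-c2ccc3c(NCCCNCc4ccco4)ccnc3c2)cc(C(F)(F)F)c1`, 237 10^-6 cm/s

These three compounds were tested in an ADME assay for permeability, using PAMPA, with a stated time of 30 min, at pH 7.4; on this read-out higher numbers stand for higher permeability and lower numbers for lower permeability. Compound 1 gives 23 10^-6 cm/s, level with compound 2 within the scatter, and the two together sit at the low end of the three; compound 3 lies above both by a gap beyond the scatter. Compound 4, `COc1cccc(CNCCCNc2ccnc3cc(CCc4ccccc4)ccc23)c1O`, has not yet been measured. It differs from compound 1 in one place: phenethyl in place of cyclohexyl on an aromatic carbon.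

Among the compounds with values here, the only measured step, no change at the digits printed from compound 1 to compound 2 (within the scatter), alters a different part of the molecule and leaves the cyclohexyl untouched, so it tells little about this change; no measured pair swaps the cyclohexyl for anything else. Without a step that bears directly on the change, the expected step of a 1.3-fold higher number from compound 1 to compound 4 (0.12 log units; within the scatter) is small, with no firm direction beyond the scatter. Compound 4 is therefore estimated to give 30 10^-6 cm/s in this assay, with a range from 10 10^-6 cm/s to 90 10^-6 cm/s.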

Compound 4, apparent permeability: 23 10^-6 cm/s
Compound 4: middle estimate off by 1.3-fold (0.12 log units), on the high side, and the stated range covers the measured number.
By their numbers in this assay, from the lowest: compounds 1, 2 and 4 (each within the scatter of the next); then compound 3.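

In this assay, within the data shown here, putting phenethyl in place of cyclohexyl on this aromatic carbon gives no change at the digits printed from compound 1 to compound 4 (within the scatter), the first direct look at a change at this position. For this pair, the group can go from a non-aromatic ring to an aromatic one, and from 6 to 8 heavy atoms, without the read-out moving beyond the scatter. No measurement at hand explains why the number holds steady.

Going by these compounds, whether an amine or a carboxylic acid on this aromatic carbon would shift the number remains open, as does the effect of a longer chain ending in phenyl. On these data alone, this is also a single pair with 2-hydroxy-3-methoxyphenyl at the other end of the molecule, so whether the result holds with 5-fluoro-2-methoxyphenyl there is unknown.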